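Swapping chloro for methoxy in a paw edema series

The compounds below may be only part of what the source reports. "The series", "measured", "known", "first", "only" and "open" are said of these compounds alone.

Measured compounds:
compound 1 `CC(=O)c1ccc(OCC(=O)Nc2ccc(C(=O)/C=C/c3ccc(Cl)cc3)cc2)cc1` gives 43%
compound 2 `COc1ccc(/C=C/C(=O)c2ccc(NC(=O)COc3ccc(C(C)=O)cc3)cc2)cc1` gives 28%
compound 3 `O=C(COCc1c(-c2ccccc2)no[n+]1[O-])Nc1ccc(C(=O)/C=C/c2ccc(Cl)cc2)cc1` gives 38%

These values come from a functional assay on the whole organism (strain albino) for inhibition, with Rattus norvegicus as the target, read by paw edema, with stated times of 30 min and 1 h, at a dose of 100 mg/kg by the oral route; on this read-out higher numbers stand for more inhibition at the one dose given (going by the name of the read-out) and lower numbers for less inhibition. Compound 1 and compound 2 share a core and differ only at one spot: methoxy in place of chloro on an aromatic carbon. This change made a number 15 percentage points lower from compound 1 to compound 2 (beyond the scatter). Compound 3 carries a different core; the difference between the two cores is not broken down here. Compound 4 `COc1ccc(/C=C/C(=O)c2ccc(NC(=O)COCc3c(-c4ccccc4)no[n+]3[O-])cc2)cc1` has not yet been measured. It differs from compound 3 at the same spot, by the same change: methoxy in place of chloro on an aromatic carbon. Because the earlier change made a number 15 percentage points lower from compound 1 to compound 2 (beyond the scatter), a step of similar size is expected here, namely a number 15 percentage points lower from compound 3 to compound 4 (beyond the scatter), though this rests on a single measured pair. From compound 3 at 38%, compound 4 is therefore estimated to give 23%, with a likely range of 10% to 36% in this assay.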

Compound 4, a percentage reported as inhibition, in the whole organism at one dose (the size of the read-out at that dose, not a potency): 30%
The estimate for compound 4 lay 7 percentage points below the measured number; measured number inside the range.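

In this assay, methoxy in place of chloro gave a number 8 percentage points lower from compound 3 to compound 4 (within the scatter), so the second core does not contradict the first. Set side by side, the two steps cannot be told apart: the same change on two cores in this assay, a number 15 percentage points lower (beyond the scatter) from compound 1 to compound 2 and a number 8 percentage points lower (within the scatter) from compound 3 to compound 4, 7 percentage points apart, within the scatter of two such steps. This is consistent with the change carrying over between these two cores, but the second step alone does not establish a real loss of inhibition, and two pairs cannot fix a typical step size.

The compounds shown carry only chloro or methoxy at this place, so how a fluoro, an amine or a carboxylic acid there would read remains open. Going by these compounds, whether the change carries to a third core, or holds at other doses, also remains open.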